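The source may report more compounds than this note shows. Statements on the series, on what has been measured and on what is new or still open speak of the compounds shown alone.

Values so far in an ADME assay on microsomes from liver (Homo sapiens) for metabolic stability; a lower number here means that the compound disappears faster, a higher number that the compound lasts longer
- compound 1 `Cn1c(=O)oc2cc(Nc3cc4c(cn3)ncn4CC3CC3)ccc21` gives 1.22 h
- compound 2 `CN1C(=O)COc2cc(Nc3ccc4ncn(CC5CC5)c4n3)cnc21` gives 0.233 h
- compound 3 `Cc1cc(Nc2cnc3c(c2)OCC(=O)N3C)nc2c1ncn2CC1CC1` gives 0.483 h

Compound 3 holds the middle of these three numbers, above compound 2 and below compound 1. Compound 4 `CN1C(=O)COc2cc(Nc3cc(C(F)(F)F)c4ncn(CC5CC5)c4n3)cnc21` differs from compound 3 by trifluoromethyl in place of methyl on an aromatic carbon. Within the data shown here, one measured step bears on this carbon: a 2.1-fold higher number from compound 2 to compound 3 (0.32 log units; beyond the scatter) is modest and beyond the scatter, with methyl in place of hydrogen. Among the measured compounds shown here, no measured compound carries trifluoromethyl, so this support is thin. In this assay the expected step is upward and smaller than that one, estimated as a 1.4-fold higher number from compound 3 to compound 4 (0.16 log units; within the scatter) for now. For compound 4 the expected half-life is 0.7 h (0.3 h to 1.5 h).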

Compound 4, half-life: 1.05 h
For compound 4 the middle estimate is 1.5-fold (0.18 log units) below the measured one; low and high end bracket the measured number.
By their numbers in this assay, from the lowest: compound 2; then compound 3; then compounds 4 and 1 (each within the scatter of the next).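

In this assay trifluoromethyl on this aromatic carbon goes beyond methyl, giving a 2.2-fold higher number from compound 3 to compound 4 (0.34 log units; beyond the scatter) and, measured against hydrogen, a 4.5-fold higher number from compound 2 to compound 4 (0.65 log units; beyond the scatter) for the full replacement. Across compound 2, compound 3 and compound 4 the number therefore rises with each replacement at this one carbon, and each rise lies beyond the scatter. Nothing at hand gives a reason for these rises. Going by these compounds, what an amine, a nitrile or a chlorine atom on this carbon would give stays open. On these data alone, whether trifluoromethyl has the same effect on the core of compound 1 also stays open.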